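Removing the Chain from the Ring Nitrogen of Compound 2

The compounds below may be only part of what the source reports. "The series", "measured", "known", "first", "only" and "open" are said of these compounds alone.

In a functional assay on ileum for inhibition of histamine H1 receptor (Cavia porcellus) (a lower number here means a stronger inhibitor, a higher number a weaker inhibitor), compound 1 `CCOCCn1c(N2CCN(C)CC2)nc2ccccc21` gives 10 nM. Among the compounds with values here, compound 2 `CC(C)CCn1c(N2CCN(C)CC2)nc2ccccc21` carries a different chain on the ring nitrogen and gives 1400 nM in this assay; of the two numbers measured so far, compound 2 holds the higher one, and the two are separated by the step of a 140-fold higher number from compound 1 to compound 2 (2.15 log units; beyond the scatter). Compound 3 `CN1CCN(c2nc3ccccc3[nH]2)CC1` has not been measured; it differs from compound 2 in one place: hydrogen in place of isopentyl on an aromatic nitrogen. Within the data shown here, only the step from compound 1 to compound 2 bears on this change, and it shows that altering the chain on that nitrogen moves the number strongly. That step exchanged one group on the chain rather than removing the chain, so it leaves the direction for compound 3 open. Compound 3 is therefore expected to give about 3000 nM, with a likely range from 400 nM to 20000 nM. This corresponds to an expected step of a 2.1-fold higher number from compound 2 to compound 3 (0.33 log units; beyond the scatter).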

Compound 3, half-maximal inhibitory concentration: > 3000 nM
Compound 3 was reported as a limit (the forecaster's own chance of this, stated with the estimate: 15%); the middle value lies on the limit itself.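

In this assay compound 3 is reported only as a limit, > 3000 nM. Replacing isopentyl with hydrogen on the aromatic nitrogen gives an at least 2.1-fold higher number from compound 2 to compound 3 (0.33 log units; beyond the scatter), which settles the direction that the earlier step left open: removing this chain brings no gain over compound 2. Replacing 2-ethoxyethyl with hydrogen at the same nitrogen gives an at least 300-fold higher number from compound 1 to compound 3 (2.47 log units; beyond the scatter), so the strength of compound 1 depends on its chain and not on the shared core alone.

As far as these compounds go, with only a limit for compound 3, the full size of both steps remains unknown. The compounds shown also leave open how the number would respond to a 2-methoxyethyl chain, or to a chain ending in an amine, on this nitrogen.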